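Thiophen-2-yl for pyridin-2-yl: a small step expected

A few compounds are considered here, and "the series" means these few. Any claim that something is new, unique, unknown or untested is made for them only; others in the source may bear on it.

Compound 1 `O=C(Nc1ccc(-c2cscn2)cc1)C1CN(Cc2ccc(F)c(F)c2)C1` gives > 20000 nM in a functional assay on A-375 cells (Homo sapiens) for antiproliferative activity (on this read-out higher numbers stand for weaker inhibition and lower numbers for stronger inhibition), and this is a limit of the assay, not a number. For the measured compounds named here, compound 2 `O=C(Nc1ccc(-c2ccccn2)cc1)C1CCCN(Cc2ccc(F)c(F)c2)C1` gives 9000 nM in this assay and so holds the only actual number so far.

Compound 3 `O=C(Nc1ccc(-c2cccs2)cc1)C1CCCN(Cc2ccc(F)c(F)c2)C1` has thiophen-2-yl in place of pyridin-2-yl on an aromatic carbon, para to a large group (thiophen-2-yl in place of pyridin-2-yl on an aromatic carbon). Going by the values given here, no measured step bears on this exchange, so no direction is favoured and no change beyond the scatter is expected in this assay for it. The expected step runs a 1.1-fold lower number from compound 2 to compound 3 (0.05 log units; within the scatter) and stays within the scatter. The expectation therefore stays close to compound 2 (9000 nM). For compound 3 the estimated value is 8000 nM with an expected range (3000 nM to 20000 nM).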

Compound 3, half-maximal inhibitory concentration: 390 nM
Beside the measured number, compound 3's estimate is 21-fold (1.31 log units) above it; measured number outside the range, below it.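

On an aromatic carbon para to a large group, the choice of ring is far from neutral: in this assay, thiophen-2-yl in place of pyridin-2-yl gives a 23-fold lower number from compound 2 to compound 3 (1.36 log units; beyond the scatter). The two groups match in their counts of donors, acceptors and net charge, so those counts do not separate them; they differ in ring size and in the hetero atom, sulfur for nitrogen. No measurement shown accounts for the size of this step.

From the compounds shown here alone, whether the gain follows the sulfur, the five-membered ring or both stays open, and a plain phenyl or a furan-2-yl ring at this position would separate these. Going by these compounds, compound 1 holds a limit, not a number, and differs from compound 2 in more than one place, so whether thiophen-2-yl would help on its core also stays open.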